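The source may hold more compounds than are shown below. What is called first, only, known or untested is meant among the compounds shown, and "the series" means these compounds.

Compound 1 `O=C(CNC(=O)c1ccc(Cl)s1)Nc1ccc(N2CCOCC2=O)cc1` and compound 2 `C[C@@H](NC(=O)c1ccc(Cl)s1)C(=O)Nc1ccc(N2CCOCC2=O)cc1` share one core and differ only by a methyl on the chain. In an assay on isolated protein for inhibition of Trypsin (Homo sapiens) (a higher number here means a weaker inhibitor, a lower number a stronger inhibitor), compound 1 gives > 10000 nM, which is a limit of the assay and not a number. Compound 2 likewise gives > 10000 nM in this assay, again a limit. The step that the two limits leave unreadable from compound 1 to compound 2 stays unreadable because the limit of > 10000 nM in this assay, at which 2 of the 2 values shown sit, holds both values. Compound 2 therefore stands at the limit itself, without a number of its own. Compound 3 `CC[C@@H](NC(=O)c1ccc(Cl)s1)C(=O)Nc1ccc(N2CCOCC2=O)cc1` differs from compound 2 by methyl in place of hydrogen on a saturated chain carbon, two bonds along the chain from an amide-type nitrogen and a carbonyl carbon. Among the compounds with values here, the only measured step concerns a different position on the chain and has no readable size; it offers neither direction nor magnitude for the present change. Compound 3 is thus expected to remain at the limit, with an expected step that the limit leaves unreadable from compound 2 to compound 3 of no size beyond the scatter. The estimate for compound 3 in this assay is 20000 nM, within a range from 8000 nM to 60000 nM.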

Compound 3, half-maximal inhibitory concentration: > 10000 nM
Compound 3: only a limit was reported; the forecaster's own chance of this, stated with the estimate: 90%; the middle value is on the limit's open side.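

Within the data shown here, no step among compound 1, compound 2 and compound 3 can be read, because their values give only a limit of the assay and no number: the limit of > 10000 nM in this assay, at which 3 of the 3 values shown sit.

In this assay the compounds shown leave open whether hydrogen, methyl or ethyl on the chain makes any difference.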